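Methyl to bromo swap carried onto a second core

This account rests on a few compounds, and the source may have more. Where it says the series, first, only, none or still open, it means among the compounds named here.

Measured in a functional assay on HONE1 cells (Homo sapiens) for cytotoxicity, read by sulforhodamine B assay, with a stated time of 24 h; on this read-out higher numbers stand for weaker inhibition and lower numbers for stronger inhibition:
compound 1 `Cc1ccc(NC(=S)Nn2c(S)nnc2-c2ccncc2)cc1` — 1290 nM
compound 2 `S=C(Nc1ccc(Br)cc1)Nn1c(S)nnc1-c1ccncc1` — 1680 nM
compound 3 `Cc1ccc(Nc2nn3c(-c4ccncc4)nnc3s2)cc1` — 3280 nM

Compound 1 and compound 2 share one core; compound 3 `Cc1ccc(Nc2nn3c(-c4ccncc4)nnc3s2)cc1` and the unmeasured compound 4 `Brc1ccc(Nc2nn3c(-c4ccncc4)nnc3s2)cc1` share another. The difference between the two cores is not broken down here. Within the first pair the change is bromo in place of methyl on an aromatic carbon and it gave a 1.3-fold higher number from compound 1 to compound 2 (0.11 log units; within the scatter). The change from compound 3 to compound 4 is bromo in place of methyl on an aromatic carbon, the same change at the same kind of place. Compound 3 carries the highest number of the three; its gap to compound 2 lies within the scatter, while its gap to compound 1 lies beyond it. On this basis the step from compound 3 to compound 4 in this assay is expected to be a 1.3-fold higher number from compound 3 to compound 4 (0.11 log units; within the scatter), resting on the step from compound 1 to compound 2 being a 1.3-fold higher number from compound 1 to compound 2 (0.11 log units; within the scatter). Compound 4 is thus estimated at 4200 nM, with a range from 2000 nM to 9000 nM, and no limit is expected.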

Compound 4, half-maximal inhibitory concentration: 2220 nM
Compound 4: the middle estimate sits 1.9-fold (0.28 log units) above what was measured; measured number inside the range.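

In this assay the change from 4-methylphenyl to 4-bromophenyl on the core of compound 3 gives a 1.5-fold lower number from compound 3 to compound 4 (0.17 log units; within the scatter). Set beside the same change on the core of compound 1, the two steps do not differ by more than repeated measurements would: the same change on two cores in this assay, a 1.3-fold higher number (0.11 log units; within the scatter) from compound 1 to compound 2 and a 1.5-fold lower number (0.17 log units; within the scatter) from compound 3 to compound 4, 1.9-fold (0.28 log units) apart, within the scatter of two such steps. On these two pairs the swap therefore carries from one core to the other as a step within the scatter on both, but neither step can be told from no change, so this shows no shared effect of the swap and says nothing about a larger step or about any other change on these cores.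

The compounds shown hold only methyl and bromo at this place, so it remains open whether an amine, a methoxy group or a carboxylic acid there would move the number beyond the scatter on either core. Also open is what the difference between the two cores itself contributes, as no pair shown isolates it.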